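The source may hold more compounds than are shown below. What is called first, only, known or untested is meant among the compounds shown, and "the series" means these compounds.

In a functional assay on HepG2 cells (Homo sapiens) for cytotoxicity, with a stated time of 72 h (on this read-out lower numbers stand for an effect already at smaller amounts and higher numbers for an effect only at larger amounts of compound), three related compounds have so far given only limits and no numbers. Compound 1 `C=C[C@@](C)(/C=C/c1ccc(O)cc1)CC/C=C(C)/C=C/C(=O)OCc1ccccc1` is reported at > 52000 nM, which is a limit. Compound 2 `C=C[C@@](C)(/C=C/c1ccc(O)c(/C=C/c2ccc(F)cc2)c1)CCC=C(C)C` is reported at > 52000 nM, also a limit. Compound 3 `COc1ccc(/C=C/[C@@](C)(/C=C/c2ccc(O)c(C=O)c2)CCC=C(C)C)cc1` is reported at > 26000 nM, likewise a limit. Going by these compounds, compound 3 therefore stands at the limit of > 26000 nM in this assay, at which 1 of the 3 values shown sits, and its true position beyond that is unknown. Compounds 1 and 2 stand at the limit of > 52000 nM in this assay, at which 2 of the 3 values shown sit.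

Compound 4 `COc1ccc(/C=C/[C@@](C)(/C=C/c2ccc(O)cc2)CCC=C(C)C)cc1` has hydrogen in place of formyl on an aromatic carbon, ortho to a hydroxy group, and the change is counted as hydrogen in place of formyl on an aromatic carbon. Going by the values given here, no measured pair shows the effect of this change, so the expectation rests on compound 3 and its limit of > 26000 nM. In this assay, no step beyond the usual scatter is expected, and so no direction is predicted. The estimate is a step that the limit leaves unreadable from compound 3 to compound 4, which is expected to remain small. Compound 4 is expected at 40000 nM, with an estimated range of 15000 nM to 100000 nM, and it may well be reported only as a limit.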

Compound 4, half-maximal effective concentration: > 52000 nM
Compound 4 ended at the assay's limit; the forecaster's own chance of this, stated with the estimate: 75%; middle value at least 1.3-fold (0.11 log units) from the limit.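

Compound 3 and compound 4 are both reported only as limits in this assay, and the step between them cannot be read. The compounds shown leave open whether hydrogen in place of formyl changes the read-out at all, and where any of the four compounds truly stands beyond its limit.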